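Defining Two Ring Stereocentres in a Dimeric Sulfonamide Series

A few compounds are considered here, and "the series" means these few. Any claim that something is new, unique, unknown or untested is made for them only; others in the source may bear on it.

The account concerns three measured dimeric sulfonamides and one that has not yet been tested, all examined in an assay on cells (Kidney epithelial cell, kidney) for inhibition of sodium/hydrogen exchanger 3 (Homo sapiens), read by fluorescence, in the presence of a further agent that is not named here; a lower number here means a stronger inhibitor, a higher number a weaker inhibitor. Compound 1 `CN1Cc2c(Cl)cc(Cl)cc2C(c2cccc(S(=O)(=O)NCCOCCOCCNS(=O)(=O)c3cccc(C4CN(C)Cc5c(Cl)cc(Cl)cc54)c3)c2)C1` has the shortest linker of the group and gives 5010 nM in this assay. Compound 3 `CN1Cc2c(Cl)cc(Cl)cc2[C@H](c2cccc(S(=O)(=O)NCCNC(=O)C(O)C(O)NCCNS(=O)(=O)c3cccc([C@@H]4CN(C)Cc5c(Cl)cc(Cl)cc54)c3)c2)C1` carries a dihydroxy-diamide link between two short chains and gives 1000 nM. Compound 2 `CN1Cc2c(Cl)cc(Cl)cc2C(c2cccc(S(=O)(=O)NCCOCCOCCOCCNC(=O)C(O)C(O)NCCOCCOCCOCCNS(=O)(=O)c3cccc(C4CN(C)Cc5c(Cl)cc(Cl)cc54)c3)c2)C1` shares that central link but with longer oxygen-containing chains; in this assay compound 2 gives 79.4 nM, the lowest of the three numbers, with compound 3 the nearest of the others and compound 1 the furthest, both gaps lying beyond the scatter.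

Compound 4 `CN1Cc2c(Cl)cc(Cl)cc2[C@H](c2cccc(S(=O)(=O)NCCOCCOCCOCCNC(=O)C(O)C(O)NCCOCCOCCOCCNS(=O)(=O)c3cccc([C@@H]4CN(C)Cc5c(Cl)cc(Cl)cc54)c3)c2)C1` is the next compound. Set against compound 2 the change is the two compounds have the same atoms and bonds; at least one stereo element is drawn with a configuration in one of them and without one in the other: 2 of 4 stereo elements differ; a stereocentre at a saturated ring carbon is drawn without a configuration in compound 2 and S in compound 4; a stereocentre at a saturated ring carbon is drawn without a configuration in compound 2 and S in compound 4. No atom leaves and none enters; the two ring carbons that were left undefined in compound 2 are now both drawn as S in compound 4. Among the measured compounds shown here, nothing among the measured pairs separates a defined from an undefined drawing of these centres, so the direction of any step cannot be read from them. Compound 4 is expected to sit close to compound 2, with a step of a 1.6-fold lower number from compound 2 to compound 4 (0.20 log units; within the scatter) that may well stay within the scatter, and its value in this assay is estimated at 50 nM, within a range from 15 nM to 250 nM.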

Compound 4, half-maximal inhibitory concentration: 1.26 nM
For compound 4 the middle estimate is 40-fold (1.60 log units) above the measured one; the whole stated range lies above it.
By their numbers in this assay, from the lowest: compound 4; then compound 2; then compound 3; then compound 1.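

In this assay, drawing the two ring stereocentres as S gives a 63-fold lower number from compound 2 to compound 4 (1.80 log units; beyond the scatter), with no atom or bond altered. The earlier compounds shown here could not show this, since they differ from one another in their chains or central link and no pair among them isolates the drawing of these centres. The result shows that the configuration at these two ring carbons is itself a major variable in this series, and the only structural difference that goes with this large step is the following: the fact that one of compounds 2 and 4 is drawn with a defined configuration and the other without, at the place where they differ

The compounds shown do not reveal how a form drawn as R at one or both ring carbons would read, or what mixture of forms, if any, lies behind the undefined drawing of compound 2, so the contribution of each configuration remains unresolved. They also leave open whether defining these centres would have a similar effect on the shorter chain of compound 1, or in a compound with a carboxylic acid or an amine in place of the hydroxyl groups of the central link.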